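A few compounds are considered here, and "the series" means these few. Any claim that something is new, unique, unknown or untested is made for them only; others in the source may bear on it.

The measured compounds in a functional assay for inhibition, with Homo sapiens as the target; on this read-out lower numbers stand for stronger inhibition and higher numbers for weaker inhibition:

Compound 1 `O=C(O)CCNC(=O)c1cc2cc(CCC3CCNCC3)sc2s1` gives 410 nM.
Compound 2 `O=C(NCc1ccccc1)N[C@@H](CNC(=O)c1cc2cc(CCC3CCNCC3)sc2s1)C(=O)O` gives 76 nM.
Compound 3 `O=C(O)CCNC(=O)c1cc2sc(CCC3CCNCC3)cc2s1` gives 500 nM.

Compound 1 and compound 3 are built from the same atoms joined differently; the difference between the two cores is not broken down here. In this assay their values lie within the usual scatter of each other, so nothing can be said about their order. Compound 2 arises from compound 1 by a single change: (benzylcarbamoyl)amino in place of hydrogen on a saturated chain carbon bound to a carbonyl carbon and a saturated chain carbon. That change brought a 5.4-fold lower number from compound 1 to compound 2 (0.73 log units; beyond the scatter), a clear gain in inhibition.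

Compound 4 `O=C(NCc1ccccc1)N[C@@H](CNC(=O)c1cc2sc(CCC3CCNCC3)cc2s1)C(=O)O` has not yet been measured. It stands to compound 3 exactly as compound 2 stands to compound 1: (benzylcarbamoyl)amino in place of hydrogen on a saturated chain carbon bound to a carbonyl carbon and a saturated chain carbon. The place of the change is described in the same words for both pairs, so this is the same change made on the other core.

Because compound 3 gives 500 nM and the same change produced a 5.4-fold lower number from compound 1 to compound 2 (0.73 log units; beyond the scatter), compound 4 is expected to show a step of about a 5.3-fold lower number from compound 3 to compound 4 (0.72 log units; beyond the scatter). Since the expectation rests on a single earlier example, the range is kept wide. Compound 4 is therefore estimated at 95 nM in this assay, with an expected span from 40 nM to 250 nM.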

Compound 4, half-maximal inhibitory concentration: 36 nM
The estimate for compound 4 lay 2.6-fold (0.42 log units) above the measured number; measured number below the stated range.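

On the second core the change again lowered the number in this assay, with a 14-fold lower number from compound 3 to compound 4 (1.14 log units; beyond the scatter), so the gain seen on the core of compound 1 also appeared on the core of compound 3. Set side by side, the two steps do not differ by more than the scatter allows: the same change on two cores in this assay, a 5.4-fold lower number (0.73 log units; beyond the scatter) from compound 1 to compound 2 and a 14-fold lower number (1.14 log units; beyond the scatter) from compound 3 to compound 4, 2.6-fold (0.41 log units) apart, within the scatter of two such steps. Among the compounds shown here, this shows that (benzylcarbamoyl)amino in place of hydrogen gave a gain of comparable size on both cores, but with only two pairs it does not show that the step is truly larger on one core than on the other, nor that the change would carry over to any further core.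

The compounds shown leave open which part of the (benzylcarbamoyl)amino group matters, and whether a plain amine, an acetamide or a longer chain in place of the benzyl group at the same saturated chain carbon would give a similar step on either core. From the compounds shown here alone, it also remains open whether the step would persist with a methyl ester or a primary amide in place of the carboxylic acid.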